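A few compounds are considered here, and "the series" means these few. Any claim that something is new, unique, unknown or untested is made for them only; others in the source may bear on it.

Measured compounds:
compound 1 `CN(C)CCC(OC(=O)c1cc2ccccc2n1C)c1ccc(Cl)cc1` — 1380 nM
compound 2 `CN(C)CC[C@H](NC(=O)c1ccc2ccccc2c1)c1ccc(Cl)cc1` — 407 nM
compound 3 `Cc1cccc(C(=O)NC(CCN(C)C)c2ccc(Cl)cc2)c1C` — 3630 nM

All three compounds were tested in an assay on NIH3T3 cells with Urotensin-2 receptor (Homo sapiens) as the target; on this read-out higher numbers stand for an effect only at larger amounts of compound and lower numbers for an effect already at smaller amounts. On these numbers compound 3 stands at the highest value of the three: compound 1 sits lower, and compound 2 lower still, each of these gaps lying beyond the usual scatter. Compound 3 is therefore the one of the three that needs the largest amount to show its effect.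

Compound 4 `Cc1ccc(C(=O)NC(CCN(C)C)c2ccc(Cl)cc2)c(C)c1` has not yet been measured. It is built from the same atoms as compound 3, joined differently: 2,4-dimethylphenyl in place of 2,3-dimethylphenyl on a carbonyl carbon. Going by the values given here, no pair among the measured compounds shows this particular change, so there is no measured step to lean on. With nothing in the data pointing either way, the expected step from compound 3 to compound 4 in this assay is a 1.2-fold lower number from compound 3 to compound 4 (0.08 log units; within the scatter), which amounts to none beyond the scatter in either direction. Compound 4 is accordingly estimated at 3000 nM, with a range from 1000 nM to 9000 nM.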

Compound 4, half-maximal effective concentration: 1550 nM
Beside the measured number, compound 4's estimate is 1.9-fold (0.29 log units) above it; the range from low to high includes it.
By their numbers in this assay, from the lowest: compound 2; then compounds 1 and 4 (each within the scatter of the next); then compound 3.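

Swapping 2,3-dimethylphenyl for 2,4-dimethylphenyl on a carbonyl carbon gives a 2.3-fold lower number from compound 3 to compound 4 (0.37 log units; beyond the scatter) in this assay, a modest step but the first one in this set that can be read from a single change. The earlier compounds shown here differed from one another in more than one place, so they could not show that this position responds to where the methyl groups sit on the ring, even when the two groups have the same atoms, the same ring type and the same counts of hydrogen-bond donors and acceptors. Nothing available here accounts for the size or direction of this step.

This single pair leaves open whether the trend extends to other arrangements at the same place, such as 3,4-dimethylphenyl or 2,6-dimethylphenyl, or whether it holds when the methyl groups give way to other groups, as in 2,4-dichlorophenyl. It also leaves open whether the same swap would give a similar step if the dimethylamino group at the end of the chain were replaced by a pyrrolidine.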